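The source may report more compounds than this note shows. Statements on the series, on what has been measured and on what is new or still open speak of the compounds shown alone.

Compound 1 `CCCCCCCCCCOc1cc(OC)c(Br)cc1C(C)=O`: 35100000 nM
Compound 2 `CCCCOc1cc(OC)ccc1C(C)=O`: 43300000 nM
Compound 3 `CCCCCCCCOc1cc(OC)ccc1C(C)=O`: 40000000 nM

In a functional assay, with a stated time of 30 min (a lower number here means a stronger inhibitor, a higher number a weaker inhibitor), compound 3 gives 40000000 nM, which lies within the usual scatter of the numbers for both compound 1 and compound 2. The next compound to be tested is compound 4 `CCCCCCCCCCOc1cc(OC)ccc1C(C)=O`. It differs from compound 3 by one change: ethyl in place of hydrogen on a saturated chain carbon, eight bonds along the chain from an oxygen on an aromatic ring.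

Among the compounds with values here, one measured step bears on this change, as it also extends the chain on the same oxygen. This step, with butyl in place of hydrogen, is a 1.1-fold lower number from compound 2 to compound 3 (0.03 log units; within the scatter), and it stays within the scatter. A step beyond the scatter is therefore not expected here. The estimated step is a 1.1-fold lower number from compound 3 to compound 4 (0.02 log units; within the scatter). The expected value for compound 4 is 38000000 nM, with an estimated range of 21000000 nM to 70000000 nM.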

Compound 4, half-maximal inhibitory concentration: 40100000 nM
For compound 4 the middle estimate is 1.1-fold (0.02 log units) below the measured one; measured number inside the range.
By their numbers in this assay, from the lowest: compounds 1, 3, 4 and 2 (each within the scatter of the next).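

Extending the chain by ethyl, eight bonds along from the oxygen on the aromatic ring, leaves the result in this assay within the scatter (a 1.0-fold higher number from compound 3 to compound 4 (0.00 log units; within the scatter)). Hexyl at the position four bonds along the chain also stays within the scatter (a 1.1-fold lower number from compound 2 to compound 4 (0.03 log units; within the scatter)), and so does hydrogen in place of bromo on the aromatic carbon (a 1.1-fold higher number from compound 1 to compound 4 (0.06 log units; within the scatter)). No supporting measurement is available to explain these results.

Still open, on these data alone, is whether a longer chain, or an amine or carboxylic acid at the chain's end, would give a step beyond the scatter. Also open, as far as these compounds go, is whether replacing bromo has the same outcome with a shorter chain.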